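The compounds below may be only part of what the source reports. "The series", "measured", "known", "first", "only" and "open" are said of these compounds alone.

Measured compounds:
Compound 1, `COc1cccc(C(=O)NCc2ccc(CNS(=O)(=O)c3ccc(C)cc3)cc2)c1`, 10 nM
Compound 2, `Cc1ccc(S(=O)(=O)NCc2ccc(CNC(=O)c3c(Cl)cc(Cl)cc3Cl)cc2)cc1`, 10 nM

Both compounds were tested in an assay on MDA-MB-231 cells for binding affinity to C-X-C chemokine receptor type 4 (Homo sapiens), read by immunofluorescence and microscopy, with stated times of 10 min and 30 min; on this read-out lower numbers stand for an effect already at smaller amounts and higher numbers for an effect only at larger amounts of compound. Compound 1 gives 10 nM there, and compound 2 gives 10 nM, so compound 2 stands level with compound 1 at the digits shown; the step of no change at the digits printed from compound 1 to compound 2 (within the scatter) lies within the scatter of the measurement.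

The unmeasured compound 3, `Cc1ccc(S(=O)(=O)NCc2ccc(CNC(=O)c3cccc(F)c3)cc2)cc1`, differs from compound 2 only at the carbonyl carbon: 3-fluorophenyl in place of 2,4,6-trichlorophenyl on a carbonyl carbon. Within the data shown here, the one measured step that bears on this change is no change at the digits printed from compound 1 to compound 2 (within the scatter), where the aryl group on that same carbonyl carbon was exchanged between 3-methoxyphenyl and 2,4,6-trichlorophenyl without any movement beyond the scatter. A third aryl group at that position, 3-fluorophenyl, is therefore expected to behave in the same way, with no step beyond the scatter in this assay.

For compound 3 the estimate is 10 nM, within a range from 4 nM to 25 nM. The step this estimate implies is no change at the digits printed from compound 2 to compound 3 (within the scatter), expected to be no larger than the scatter.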

Compound 3, effective concentration (reported as EC, without a stated level of effect): 1 nM
The estimate for compound 3 lay 10-fold (1.00 log units) above the measured number; measured number below the stated range.
By their numbers in this assay, from the lowest: compound 3; then compounds 1 and 2 (each within the scatter of the next).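

In this assay, the aryl group on the carbonyl carbon proves not to be an indifferent position: 3-fluorophenyl in place of 2,4,6-trichlorophenyl gives a 10-fold lower number from compound 2 to compound 3 (1.00 log units; beyond the scatter) on the shared core, whereas the earlier exchange of aryl groups there gave only no change at the digits printed from compound 1 to compound 2 (within the scatter) and so showed no sensitivity at all. Fluoro in place of methoxy on an aromatic carbon gives a 10-fold lower number from compound 1 to compound 3 (1.00 log units; beyond the scatter) as well, so a change of one substituent on the ring is enough to move the number beyond the scatter, and the agreement of compound 1 and compound 2 did not mean that any aryl group would serve equally. Nothing available here accounts for why this exchange moves the number.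

The compounds shown leave open whether the fluorine itself matters, since plain phenyl, 3-chlorophenyl and 3-trifluoromethylphenyl on the same carbonyl carbon would be needed to separate it from the mere absence of the other substituents. They also leave open whether fluoro elsewhere on the ring, as in 4-fluorophenyl, or a ring other than phenyl, such as pyridyl or cyclohexyl, would hold this lower number.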